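Benzylamide in place of the acid: expected cytotoxicity of compound 4

The compounds below may be only part of what the source reports. "The series", "measured", "known", "first", "only" and "open" are said of these compounds alone.

In a functional assay on QGY7701 cells (Homo sapiens) for cytotoxicity, read by MTT assay, with a stated time of 24 h (on this read-out higher numbers stand for weaker inhibition and lower numbers for stronger inhibition), the measured compounds gave the following.
Compound 1, `C=CC1=C(C(=O)O)C(c2ccc(F)cc2)OC1`: > 100000 nM, which is a limit of the assay and not a number.
Compound 2, `C=CC1=C(C(=O)NC(C)(C)C)C(c2ccc(Cl)c(Cl)c2)OC1`: > 100000 nM, again only a limit.
Compound 3, `C=CC1=C(C(=O)NCCCCC)C(c2ccc(OC)cc2)OC1`: > 100000 nM, again only a limit.

Compound 1 therefore sits at the limit of > 100000 nM in this assay, at which 3 of the 3 values shown sit, and no number separates it from the others. Compound 4, `C=CC1=C(C(=O)NCc2ccccc2)C(c2ccc(F)cc2)OC1`, differs from compound 1 by benzylamino in place of hydroxy on a carbonyl carbon. Among the measured compounds shown here, no measured pair shows this change. Since compound 2 and compound 3 already carry amides and reach only the limit, the step from compound 1 to compound 4 is expected to be none beyond the scatter, a number no higher from compound 1 to compound 4 (the limit leaves the size open). Compound 4 is expected to give 100000 nM, ranging from 30000 nM to 300000 nM, most likely again as a limit.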

Compound 4, half-maximal inhibitory concentration: 67600 nM
The estimate for compound 4 lay 1.5-fold (0.17 log units) above the measured number; measured number inside the range.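

Benzylamino in place of hydroxy on a carbonyl carbon gives, in this assay, the first reading here that is a number and not a limit, with an at least 1.4-fold lower number from compound 1 to compound 4 (0.17 log units; that floor lies within the scatter) as the step. On these data alone, compound 1 gives only a limit, so the true size of this step stays unknown. Compound 4 stands alone with a number: the limit of > 100000 nM in this assay, at which 3 of the 4 values shown sit.

As far as these compounds go, whether the six-membered aromatic ring of the benzylamino group matters stays open. A methylamino group or a phenethylamino group on the same carbonyl carbon would help to settle this.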